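This account rests on a few compounds, and the source may have more. Where it says the series, first, only, none or still open, it means among the compounds named here.

Measured compounds, with the half-maximal inhibitory concentration in a functional assay on HCT-116 cells (Homo sapiens) for antiproliferative activity, read by MTT assay, with a stated time of 72 h; a lower number here means a stronger inhibitor, a higher number a weaker inhibitor:
compound 1 `CN(C(=O)c1ccc(F)cc1)c1ccc2[nH]c(-c3n[nH]c4ccccc34)cc2n1`: 9270 nM
compound 2 `CN(C(=O)c1ccc(Br)cc1)c1ccc2[nH]c(-c3n[nH]c4ccccc34)cc2n1`: 6110 nM
compound 3 `CN(c1ccc2[nH]c(-c3n[nH]c4ccccc34)cc2n1)S(=O)(=O)c1ccccc1`: 6740 nM

Compound 3 sits second highest of the three numbers, with compound 2 nearest a 1.1-fold higher number from compound 2 to compound 3 (0.04 log units; within the scatter) and compound 1 furthest a 1.4-fold lower number from compound 1 to compound 3 (0.14 log units; within the scatter); all three sit within the scatter of one another.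

Compound 4 `COc1ccc(S(=O)(=O)N(C)c2ccc3[nH]c(-c4n[nH]c5ccccc45)cc3n2)cc1OC` carries 3,4-dimethoxyphenyl in place of phenyl on a sulfonyl sulfur. Among the measured compounds shown here, no measured step alters the ring on the sulfonyl sulfur, so only indirect guidance exists. For the measured compounds named here, the one aromatic substituent change, bromo for fluoro, gave a 1.5-fold lower number from compound 1 to compound 2 (0.18 log units; within the scatter), and exchanging the whole group on the nitrogen gave a 1.4-fold lower number from compound 1 to compound 3 (0.14 log units; within the scatter) and a 1.1-fold higher number from compound 2 to compound 3 (0.04 log units; within the scatter): every change so far stayed within the scatter. For compound 4 in this assay a step of a 1.1-fold lower number from compound 3 to compound 4 (0.05 log units; within the scatter) is expected, no larger than the scatter. The estimate for compound 4 is 6000 nM, with a range from 2500 nM to 15000 nM.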

Compound 4, half-maximal inhibitory concentration: 16700 nM
Compound 4: the middle estimate sits 2.8-fold (0.44 log units) below what was measured; measured number outside the range, above it.
By their numbers in this assay, from the lowest: compounds 2, 3, 1 and 4 (each within the scatter of the next, the first and the last beyond it).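

In this assay, among the compounds shown here, the group on the sulfonyl sulfur is the first place where one change passes the scatter: 3,4-dimethoxyphenyl in place of phenyl gives a 2.5-fold higher number from compound 3 to compound 4 (0.39 log units; beyond the scatter), towards a weaker inhibitor. The halogen exchange and the exchanges of the whole group on the nitrogen all stayed within the scatter, so this position is the only one shown to respond. Nothing measured here accounts for the step.

From the compounds shown here alone, whether a single methoxy group gives the same step stays open, as does how an amine or a carboxylic acid on this ring would read.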